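This account rests on a few compounds, and the source may have more. Where it says the series, first, only, none or still open, it means among the compounds named here.

Measured in a functional assay on MDA-MB-231 cells (Homo sapiens) for inhibition, read by MTT assay, with a stated time of 72 h; on this read-out higher numbers stand for weaker inhibition and lower numbers for stronger inhibition:
Compound 1 `CC(C)[C@H](NC(=O)c1cc(Cl)ccc1OCCNC(=O)O)C(=O)Nc1ccc([N+](=O)[O-])cc1Cl`: > 10000 nM (a limit)
Compound 2 `CC(C)[C@H](NC(=O)c1cc(Cl)ccc1OCCCN)C(=O)Nc1ccc([N+](=O)[O-])cc1Cl`: 6770 nM

Within the data shown here, compound 2 gives the only actual number, 6770 nM. The other result belongs to compound 1 and is a limit: the limit of > 10000 nM in this assay, at which 1 of the 2 values shown sits.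

Compound 3 `CC(C)[C@H](NC(=O)c1cc(Cl)ccc1OCCCCNC(=O)OC(C)(C)C)C(=O)Nc1ccc([N+](=O)[O-])cc1Cl` differs from compound 2 at the end of the chain: ((tert-butoxycarbonyl)amino)methyl in place of amino on a saturated chain carbon, three bonds along the chain from an oxygen on an aromatic ring. This places ((tert-butoxycarbonyl)amino)methyl in place of amino on a saturated chain carbon, three bonds along the chain from an oxygen on an aromatic ring.

Among the measured compounds shown here, one measured step bears on this change: an at least 1.4-fold lower number from compound 1 to compound 2 (0.16 log units; that floor lies within the scatter). Reading that step backwards, a carbonyl on the chain nitrogen, as in compound 3, is expected to bring a modest move towards a higher number in this assay, perhaps none beyond the scatter. The expected change is a 1.3-fold higher number from compound 2 to compound 3 (0.12 log units; within the scatter). For compound 3 the estimated value is 9000 nM, expected to fall between 4000 nM and 20000 nM.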

Compound 3, half-maximal inhibitory concentration: > 10000 nM
Compound 3 gave a limit, no number (the forecaster's own chance of this, stated with the estimate: 50%); middle value at least 1.1-fold (0.04 log units) away from the limit.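

In this assay compound 3 gives > 10000 nM, which is a limit and not a number, so the ((tert-butoxycarbonyl)amino)methyl end group yields no measurable value here. Placing this group in place of amino gives an at least 1.4-fold higher number from compound 2 to compound 3 (0.16 log units; that floor lies within the scatter), which is only a floor, and the true size of the change stays unknown. Compound 1 and compound 3 both stand at the limit, and the step between them cannot be read: the limit of > 10000 nM in this assay, at which 2 of the 3 values shown sit.

Going by these compounds, it remains open whether the longer chain or the tert-butoxycarbonyl cap accounts for the step, a question that a free 4-aminobutyl chain on the shared core would separate. Also open, on these data alone, is how a carboxylic acid or a shorter 2-aminoethyl chain at this end would read in this assay.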